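From cyclohexylamino to (3-fluorophenyl)amino on the shared core

A few compounds are considered here, and "the series" means these few. Any claim that something is new, unique, unknown or untested is made for them only; others in the source may bear on it.

- Compound 1 `O=C1C(N2CCCCC2)=CC(=O)c2c1nc1n2[C@H]2OC[C@@H](O)[C@H]2OC1`: > 8000 nM (a limit)
- Compound 2 `COc1cccc(NC2=CC(=O)c3c(nc4n3[C@H]3OC[C@@H](O)[C@H]3OC4)C2=O)c1`: 3340 nM
- Compound 3 `O=C1C(NC2CCCCC2)=CC(=O)c2c1nc1n2[C@H]2OC[C@@H](O)[C@H]2OC1`: > 16000 nM (a limit)

In a functional assay on ECa-109 cells for inhibition, with ECa-109 cell line (Homo sapiens) as the target, read by sulforhodamine B assay (a lower number here means a stronger inhibitor, a higher number a weaker inhibitor), compound 3 has only a limit, > 16000 nM, and no exact number. Compound 4 `O=C1C(Nc2cccc(F)c2)=CC(=O)c2c1nc1n2[C@H]2OC[C@@H](O)[C@H]2OC1` carries 3-fluorophenyl in place of cyclohexyl on an amine nitrogen. The nearest guide is the opposite swap, an at least 4.7-fold higher number from compound 2 to compound 3 (0.68 log units; beyond the scatter), which lies beyond the scatter. The step of an at least 2.3-fold lower number from compound 1 to compound 2 (0.37 log units; beyond the scatter) also favours the aromatic group, whereas a step that the two limits leave unreadable from compound 1 to compound 3 has no readable size. For the measured compounds named here, compound 2 is the only one with an exact number, 3340 nM, and no 3-fluorophenyl compound has been measured. The expected change is an at least 4.5-fold lower number from compound 3 to compound 4 (0.66 log units; beyond the scatter), a clear drop in the number. For compound 4 the estimated value is 3500 nM, with an expected range from 1300 nM to 9000 nM.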

Compound 4, half-maximal inhibitory concentration: 2370 nM
Compound 4: the middle estimate sits 1.5-fold (0.17 log units) above what was measured; the measured number falls inside the stated range.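

In this assay, an at least 6.7-fold lower number from compound 3 to compound 4 (0.82 log units; beyond the scatter) and an at least 3.3-fold lower number from compound 1 to compound 4 (0.52 log units; beyond the scatter), so a second aromatic amine, not only the 3-methoxyphenyl group of compound 2, gives a lower number at this position than the non-aromatic groups. Fluoro in place of methoxy on the aromatic ring gives a 1.4-fold lower number from compound 2 to compound 4 (0.15 log units; within the scatter), so these two groups cannot be told apart here. The step from the cyclohexyl compound gives only a minimum size, because it starts from a limit: the limit of > 16000 nM in this assay, at which 1 of the 4 values shown sits.

Still open, from the compounds shown here alone, is whether a plain phenylamino group matches these two substituted rings. A benzylamino or pyridinylamino group at this position is also untested among the compounds shown.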